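Methyl in place of ethoxycarbonyl: expected return to measurable inhibition

A few compounds are considered here, and "the series" means these few. Any claim that something is new, unique, unknown or untested is made for them only; others in the source may bear on it.

Compound 3 `CCOC(=O)C(=O)Nc1cccc(C(=O)/C=C/c2ccc(O)c(OC)c2)c1` gives no number in a functional assay on U-87MG ATCC cells (Homo sapiens) for inhibition (a higher number here means a weaker inhibitor, a lower number a stronger inhibitor), only a limit: > 50 ug/mL. Its place in the series is the limit of > 50 ug/mL in this assay, at which 1 of the 3 values shown sits. In this assay compound 2 `CCCC(=O)Nc1cccc(C(=O)/C=C/c2ccc(O)c(OC)c2)c1` gives 5.56 ug/mL and compound 1 `COc1cc(/C=C/C(=O)c2cccc(NC(=O)c3c(Cl)cccc3Cl)c2)ccc1O` gives 17.8 ug/mL.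

The next change leads to compound 4 `COc1cc(/C=C/C(=O)c2cccc(NC(C)=O)c2)ccc1O`, with methyl in place of ethoxycarbonyl on a carbonyl carbon. The same carbonyl carbon has already been varied in the measured compounds. The step most relevant here is an at least 8.9-fold higher number from compound 2 to compound 3 (0.95 log units; beyond the scatter), which introduces ethoxycarbonyl in place of propyl. Ethoxycarbonyl also compares poorly with 2,6-dichlorophenyl, in an at least 2.8-fold higher number from compound 1 to compound 3 (0.44 log units; beyond the scatter). Between the other two groups, the step is a 3.2-fold lower number from compound 1 to compound 2 (0.51 log units; beyond the scatter). Both steps that introduce ethoxycarbonyl therefore raise the number beyond the scatter, and removing that group should reverse the direction. Going by the values given here, no measured compound carries methyl, so propyl in compound 2 at 5.56 ug/mL is the nearest guide, and the recovery may be incomplete.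

The expected change is an at least 5.0-fold lower number from compound 3 to compound 4 (0.69 log units; beyond the scatter), a lower number and a step beyond the scatter. For compound 4 the estimate in this assay is 10 ug/mL, with an expected range of 4 ug/mL to 30 ug/mL.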

Compound 4, half-maximal inhibitory concentration: > 50 ug/mL
Compound 4 was reported as a limit (the forecaster's own chance of this, stated with the estimate: 8%); middle value at least 5.0-fold (0.69 log units) from the limit.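

In this assay compound 4 reads as a limit, as compound 3 does, so the step between them cannot be read, and taking away ethoxycarbonyl does not by itself give a measurable value: the limit of > 50 ug/mL in this assay, at which 2 of the 4 values shown sit.

The new information concerns the propyl chain of compound 2: hydrogen in place of ethyl on the saturated chain carbon bound to the carbonyl carbon gives an at least 8.9-fold higher number from compound 2 to compound 4 (0.95 log units; beyond the scatter), so this short change on the chain is enough to lose the measurable value. Methyl in place of 2,6-dichlorophenyl gives an at least 2.8-fold higher number from compound 1 to compound 4 (0.44 log units; beyond the scatter), and across the four compounds the measurable values belong only to the propyl and 2,6-dichlorophenyl amides, while the limits belong to the methyl and ethoxycarbonyl groups.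

The compounds shown leave open where along the chain measurable inhibition begins, as ethyl, butyl or a longer chain on the same carbonyl carbon would show, and whether an unsubstituted phenyl ring keeps the value of compound 1. Going by these compounds, how far compound 3 and compound 4 lie apart beyond the limit also stays open.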